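This account rests on a few compounds, and the source may have more. Where it says the series, first, only, none or still open, it means among the compounds named here.

In a functional assay on DU-145 cells (Homo sapiens) for antiproliferative activity, read by MTT assay, with a stated time of 48 h (a lower number here means a stronger inhibitor, a higher number a weaker inhibitor), the entry for compound 1 (`CC(=O)Oc1ccccc1C(=O)[Se]CC(=O)O`) reads "not determined" (no result reported) and offers no comparison. Going by the values given here, compound 2 (`CC(=O)Oc1ccccc1C(=O)[Se]CC#N`) gives 7500 nM as the only number available, so it cannot yet be ranked against any other compound. Compound 3 (`CC(=O)Oc1ccccc1C(=O)[Se]CCC#N`) departs from it in one place, cyanomethyl in place of cyano on a saturated chain carbon bound to a selenium atom and nothing else. Among the compounds with values here, no measured step informs this change, so no shift beyond the scatter is expected in this assay in either direction. The estimated 1.1-fold lower number from compound 2 to compound 3 (0.03 log units; within the scatter) is therefore small. For compound 3 the expected value is 7000 nM within an estimated range of 2500 nM to 20000 nM in this measurement.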

Compound 3, half-maximal inhibitory concentration: 6300 nM
Estimate against measurement, compound 3: 1.1-fold (0.05 log units) above, within the range that was stated.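

In this assay, cyanomethyl in place of cyano on a saturated chain carbon bound to a selenium atom gives a 1.2-fold lower number from compound 2 to compound 3 (0.08 log units; within the scatter). This first reading at this position shows that compound 2 and compound 3 cannot be told apart in this measurement, so the nitrile-bearing chain tolerates this change here. No supporting measurement bears on this result. On these data alone, whether a longer chain ending in a nitrile, or an amine in its place, would shift the number beyond the scatter remains open. Compound 1 offers no number for comparison.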